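Extending an ethyl to propyl on the aryl urea

A few compounds are considered here, and "the series" means these few. Any claim that something is new, unique, unknown or untested is made for them only; others in the source may bear on it.

Measured compounds:
- compound 1, `Cc1ccccc1NC(=O)N[C@H](C)c1ccccc1`, 100%
- compound 2, `CCc1ccc(NC(=O)N[C@H](C)c2ccccc2)cc1`, 95%
- compound 3, `CCc1ccc(NC(=O)N[C@@H](C)c2ccccc2)cc1`, 99%

All three were tested in an ADME assay on the whole organism with Oryza sativa as the target, tested at 0.1 uM; a higher number here means a weaker effect of the compound at the concentration tested, a lower number a stronger effect. Compound 2 gives the value from which the other two numbers differ by less than the usual scatter: compound 3 shows a number 4 percentage points higher from compound 2 to compound 3 (within the scatter), and compound 1 shows a number only slightly higher. Compounds 2 and 3 are the same molecule apart from configuration (the fact that compounds 2 and 3 differ only in the configuration as drawn), so this step says nothing about adding carbon to the chain.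

Compound 4, `CCCc1ccc(NC(=O)N[C@H](C)c2ccccc2)cc1`, has not yet been measured. Compared with compound 2, the change is methyl in place of hydrogen on a saturated chain carbon, two bonds along the chain from an aromatic carbon, which at the level of the whole chain reads ethyl to propyl. Going by the values given here, no measured step alters a chain in this way, so the only guide is that all three measured numbers lie close together at this concentration. The expected step is therefore none beyond the scatter, estimated as a number 1 percentage points higher from compound 2 to compound 4 (within the scatter). For compound 4 the estimate is 96%, with a range from 85% to 100%.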

Compound 4, a percentage reported as activity, at one concentration (the size of the read-out at that concentration, not a potency): 33%
For compound 4 the middle estimate is 63 percentage points above the measured one; the whole stated range lies above it.
By their numbers in this assay, from the lowest: compound 4; then compounds 2, 3 and 1 (each within the scatter of the next).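

Going by these compounds alone, the change from ethyl to propyl on this chain matters in this assay: it gives a number 62 percentage points lower from compound 2 to compound 4 (beyond the scatter) and is the only step read so far that lies beyond the scatter. The earlier numbers all sat close together, so they gave no sign that this part of the molecule could shift the read-out at all. Here a single added methyl, which brings no ring, no hydrogen-bond donor or acceptor and no charge, is enough to produce a much stronger effect at the concentration tested.

Still open, as far as these compounds go, is whether a butyl or longer chain would continue this drop or reverse it, and whether the opposite drawn configuration of compound 4 would give a similar number. Nothing given here explains why this one extra carbon has so large an effect.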